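Ring size of the basic amine in a kinase-type series

The compounds below may be only part of what the source reports. "The series", "measured", "known", "first", "only" and "open" are said of these compounds alone.

Compounds measured so far:
Compound 1, `COc1cc2c(Oc3ccc(NC(=O)c4nn(-c5ccccc5)c(=O)cc4C)cc3F)ccnc2cc1OCCCN1CCCCC1`, gives 150 nM in a functional assay on A549 cells (Homo sapiens) for inhibition, read by MTT assay, with a stated time of 72 h; on this read-out higher numbers stand for weaker inhibition and lower numbers for stronger inhibition.
Compound 2, `COc1cc2c(Oc3ccc(NC(=O)c4nn(-c5ccccc5C)c(=O)cc4C)cc3F)ccnc2cc1OCCCN1CCCCC1`, gives 1920 nM in this assay.
Compound 3, `COc1cc2c(Oc3ccc(NC(=O)c4nn(-c5ccccc5C(F)(F)F)c(=O)cc4C)cc3F)ccnc2cc1OCCCN1CCCC1`, gives 130 nM in this assay.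

Compound 3 has the lowest of the three numbers, but compound 1 sits close by, within the scatter, so the two cannot be ranked against each other. For the measured compounds named here, compound 2 stands well apart: the change a 13-fold higher number from compound 1 to compound 2 (1.11 log units; beyond the scatter) is the only single-point step among the measured compounds, and it concerns the phenyl ring on the shared core, not the amine at the end of the chain.

Compound 4, `COc1cc2c(Oc3ccc(NC(=O)c4nn(-c5ccccc5C(F)(F)F)c(=O)cc4C)cc3F)ccnc2cc1OCCCN1CCCCC1`, differs from compound 3 by piperidin-1-yl in place of pyrrolidin-1-yl on a saturated chain carbon, three bonds along the chain from an oxygen on an aromatic ring. Going by the values given here, no measured step isolates this change. Compounds 1 and 2 carry the piperidinyl ring and compound 3 the pyrrolidinyl ring, but those compounds differ elsewhere as well, so their values cannot be read as a test of ring size alone. With nothing to suggest a shift, the step of a 1.2-fold higher number from compound 3 to compound 4 (0.06 log units; within the scatter) is expected to stay within the scatter in this assay. Compound 4 is therefore estimated at 150 nM, with a plausible range from 60 nM to 400 nM.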

Compound 4, half-maximal inhibitory concentration: 140 nM
Estimate against measurement, compound 4: 1.1-fold (0.03 log units) above; the range from low to high includes it.
By their numbers in this assay, from the lowest: compounds 3, 4 and 1 (each within the scatter of the next); then compound 2.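

In this assay, for the compounds shown here, the step of a 1.1-fold higher number from compound 3 to compound 4 (0.03 log units; within the scatter) isolates the ring at the end of the 3-(pyrrolidin-1-yl)propyl chain for the first time, and replacing it with the six-membered piperidin-1-yl ring gives no difference that can be told from the scatter. Compound 4 also completes a set of three compounds with the same piperidin-1-yl ring that differ only in one group on an aromatic carbon: trifluoromethyl in place of hydrogen gives a 1.1-fold lower number from compound 1 to compound 4 (0.03 log units; within the scatter) and remains within the scatter, while trifluoromethyl in place of methyl gives a 14-fold lower number from compound 2 to compound 4 (1.14 log units; beyond the scatter) and is a large step, so among these three only the methyl compound stands apart. Nothing measured here explains either result.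

The ring change is shown only alongside trifluoromethyl, so whether it would read the same with methyl on that aromatic carbon, as in compound 2, remains open. Also open, as far as these compounds go, is how a morpholin-4-yl ring or a dimethylamino group at the end of the chain would compare, and what a chain longer than propyl would do.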